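Replacing the 2-nitrophenyl group of compound 3

The source may report more compounds than this note shows. Statements on the series, on what has been measured and on what is new or still open speak of the compounds shown alone.

Values in a functional assay on SW-620 cells (Homo sapiens) for cytotoxicity, read by MTT assay, with a stated time of 3 days (a lower number here means that less compound is needed, a higher number that more compound is needed for the effect), for the measured compounds
compound 1 `O=C1/C(=C/c2ccccc2Cl)c2ccccc2N1c1c(Cl)cccc1Cl` gives 15 ug/mL
compound 2 `O=C1/C(=C/c2cccc(Cl)c2)c2ccccc2N1c1c(Cl)cccc1Cl` gives 50 ug/mL
compound 3 `O=C1/C(=C/c2ccccc2[N+](=O)[O-])c2ccccc2N1c1c(Cl)cccc1Cl` gives 90 ug/mL

Compound 3 sits at the top end of these numbers, without separating from its nearest neighbour (a 1.8-fold higher number from compound 2 to compound 3 (0.26 log units; within the scatter)), while a clear gap remains to the lowest value (a 6.0-fold higher number from compound 1 to compound 3 (0.78 log units; beyond the scatter)). Compound 4 `CN(C)c1ccc(/C=C2/C(=O)N(c3c(Cl)cccc3Cl)c3ccccc32)cc1` has 4-(dimethylamino)phenyl in place of 2-nitrophenyl (4-(dimethylamino)phenyl in place of 2-nitrophenyl on a double-bonded chain carbon bound to a double-bonded ring carbon). For the measured compounds named here, no measured compound carries this group, so only the modest steps on changing the group at this place bear on it (a 3.3-fold higher number from compound 1 to compound 2 (0.52 log units; beyond the scatter)) and (a 6.0-fold higher number from compound 1 to compound 3 (0.78 log units; beyond the scatter)). With compound 3 at the top end, a modest step to a lower number is expected (a 2.0-fold lower number from compound 3 to compound 4 (0.30 log units; within the scatter)). Compound 4 is estimated at 45 ug/mL with an expected range (14 ug/mL to 140 ug/mL).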

Compound 4, concentration for half-maximal effect: > 100 ug/mL
Compound 4: a limit, no number; the forecaster's own chance of this, stated with the estimate: 15%; at least 2.2-fold (0.34 log units) between middle value and limit.
By their numbers in this assay, from the lowest: compound 1; then compounds 2 and 3 (each within the scatter of the next). At a limit, above all of these: compound 4.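

Compound 4 gives only a limit in this assay, not a number: the limit of > 100 ug/mL in this assay, at which 1 of the 4 values shown sits.

For the compounds shown here, at this place, on a double-bonded chain carbon bound to a double-bonded ring carbon, 4-(dimethylamino)phenyl is the first group to reach that limit, and it separates clearly only from the 2-chlorophenyl group: an at least 6.6-fold higher number from compound 1 to compound 4 (0.82 log units; beyond the scatter). The other floors do not set it apart from the 3-chlorophenyl or 2-nitrophenyl groups: an at least 2.0-fold higher number from compound 2 to compound 4 (0.30 log units; that floor lies within the scatter) and an at least 1.1-fold higher number from compound 3 to compound 4 (0.04 log units; that floor lies within the scatter).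

From the compounds shown here alone, how far compound 4 lies past compound 3 stays open. Also open, going by these compounds, is how a plain phenyl, a 4-chlorophenyl or a 4-aminophenyl group would read at this place.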